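Chlorine for fluorine on a second, fluorinated core

A few compounds are considered here, and "the series" means these few. Any claim that something is new, unique, unknown or untested is made for them only; others in the source may bear on it.

Compound 1 `O=C(Nc1ccc(Oc2ccnc3[nH]ccc23)cc1)c1cn(-c2ccc(F)cc2)c2ccccc2c1=O` and compound 2 `O=C(Nc1ccc(Oc2ccnc3[nH]ccc23)cc1)c1cn(-c2ccc(Cl)cc2)c2ccccc2c1=O` share one core and differ only in chloro in place of fluoro on an aromatic carbon. In a functional assay on A549 cells (Homo sapiens) for inhibition, read by MTT assay, with a stated time of 72 h (on this read-out higher numbers stand for weaker inhibition and lower numbers for stronger inhibition), compound 1 gives 390 nM, while compound 2 gives 650 nM, so the change produced a 1.7-fold higher number from compound 1 to compound 2 (0.22 log units; within the scatter). Compound 3 `O=C(Nc1ccc(Oc2ccnc3[nH]ccc23)c(F)c1)c1cn(-c2ccc(F)cc2)c2ccccc2c1=O` carries a second core that differs from that of compound 1 by fluoro in place of hydrogen on an aromatic carbon; in this assay compound 3 gives 290 nM, which is a 1.3-fold lower number from compound 1 to compound 3 (0.13 log units; within the scatter). Compound 4 `O=C(Nc1ccc(Oc2ccnc3[nH]ccc23)c(F)c1)c1cn(-c2ccc(Cl)cc2)c2ccccc2c1=O` has not yet been measured. It stands to compound 3 as compound 2 stands to compound 1: the difference is chloro in place of fluoro on an aromatic carbon, and the surroundings of the place of change are the same in both pairs, so this is the same change, now made on the core of compound 3. Resting on the single earlier example, the step from compound 3 to compound 4 is expected to be of similar size, namely a 1.7-fold higher number from compound 3 to compound 4 (0.23 log units; within the scatter), because the earlier step was a 1.7-fold higher number from compound 1 to compound 2 (0.22 log units; within the scatter). Compound 4 is therefore estimated at 490 nM, most likely falling between 250 nM and 950 nM.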

Compound 4, half-maximal inhibitory concentration: 320 nM
Compound 4: middle estimate off by 1.5-fold (0.19 log units), on the high side; the measured number falls inside the stated range.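

Chloro in place of fluoro on the core of compound 3 gave a 1.1-fold higher number from compound 3 to compound 4 (0.04 log units; within the scatter), and in this assay this agrees with the earlier step: the same change on two cores in this assay, a 1.7-fold higher number (0.22 log units; within the scatter) from compound 1 to compound 2 and a 1.1-fold higher number (0.04 log units; within the scatter) from compound 3 to compound 4, 1.5-fold (0.18 log units) apart, within the scatter of two such steps. Fluoro in place of hydrogen on an aromatic carbon, carried onto the chloro compounds, gave a 2.0-fold lower number from compound 2 to compound 4 (0.31 log units; beyond the scatter), which alone lies beyond the scatter but still agrees with its counterpart: the same change on two cores in this assay, a 1.3-fold lower number (0.13 log units; within the scatter) from compound 1 to compound 3 and a 2.0-fold lower number (0.31 log units; beyond the scatter) from compound 2 to compound 4, 1.5-fold (0.18 log units) apart, within the scatter of two such steps. For the compounds shown here, both changes therefore carried from one core to the other without a detectable difference, but each comparison rests on only two steps, and the chloro-for-fluoro steps are so small that this shows little effect on both cores, not a dependable shift that would hold on further cores.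

The compounds shown leave open whether larger or different groups in place of the 4-fluoro or 4-chloro substituent, such as bromo, methoxy, trifluoromethyl or an amine, would change the number in this assay. They also leave open whether either change would carry over to a core altered elsewhere.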